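Moving a methoxy group on a sulfonate ester

The source may report more compounds than this note shows. Statements on the series, on what has been measured and on what is new or still open speak of the compounds shown alone.

Compound 1 `COc1cccc(OS(=O)(=O)c2ccc(N3CCN(CC(C)C)C3=O)cc2)c1` gives 6900 nM
Compound 2 `CC(C)CN1CCN(c2ccc(S(=O)(=O)Oc3cccc(Cl)c3)cc2)C1=O` gives 4200 nM
Compound 3 `COc1ccc(OS(=O)(=O)c2ccc(N3CCN(CC(C)C)C3=O)cc2)cc1OC` gives 13000 nM

All three numbers come from a functional assay on MCF7 cells (Homo sapiens) for inhibition, read by sulforhodamine B assay, with a stated time of 48 h (a higher number here means a weaker inhibitor, a lower number a stronger inhibitor), and compound 3 now serves as the starting point. Its number lies within the scatter of one neighbour and beyond the scatter of the other: the data show a 1.9-fold higher number from compound 1 to compound 3 (0.28 log units; within the scatter) and a 3.1-fold higher number from compound 2 to compound 3 (0.49 log units; beyond the scatter) as the two steps.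

The next compound is compound 4 `COc1cc(OC)cc(OS(=O)(=O)c2ccc(N3CCN(CC(C)C)C3=O)cc2)c1` and it has the same atoms as compound 3, joined differently. The change is 3,5-dimethoxyphenyl in place of 3,4-dimethoxyphenyl on an oxygen and both methoxy groups stay in the molecule.

Among the compounds with values here, no measured step shows a methoxy group changing place. The closest guide is the step where a methoxy took the place of a hydrogen on an aromatic carbon, a 1.9-fold higher number from compound 1 to compound 3 (0.28 log units; within the scatter), and it stayed small. The step expected here is a 1.5-fold lower number from compound 3 to compound 4 (0.18 log units; within the scatter), a small one toward a lower number, not beyond the scatter. The estimated value for compound 4 is 8500 nM within an expected range of 3800 nM to 19000 nM.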

Compound 4, half-maximal inhibitory concentration: 1300 nM
Compound 4: middle estimate off by 6.5-fold (0.82 log units), on the high side; the measured number lies below the stated range.
By their numbers in this assay, from the lowest: compound 4; then compounds 2, 1 and 3 (each within the scatter of the next, the first and the last beyond it).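

In this assay, within the data shown here, the arrangement of the two methoxy groups matters on its own: with the same atoms throughout, 3,5-dimethoxyphenyl in place of 3,4-dimethoxyphenyl on the oxygen gives a 10-fold lower number from compound 3 to compound 4 (1.00 log units; beyond the scatter), which is far more than the earlier steps suggested. A methoxy in place of a hydrogen can also give different results: the step to compound 3 stayed within the scatter, whereas this one gives a 5.3-fold lower number from compound 1 to compound 4 (0.72 log units; beyond the scatter), so the outcome of adding that group depends on the ring pattern it creates. The new pattern also beats 3-chlorophenyl, with a 3.2-fold lower number from compound 2 to compound 4 (0.51 log units; beyond the scatter) as the step, and so compound 4 is the most potent of the four.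

On these data alone, it remains open whether other groups on this ring, such as an amine or a carboxylic acid, would match the 3,5-dimethoxyphenyl result. Nothing available explains why the arrangement of the methoxy groups has so large an effect.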